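Exchanging the Core Substituent of Compound 2

The compounds below may be only part of what the source reports. "The series", "measured", "known", "first", "only" and "open" are said of these compounds alone.

Compound 2 `O=[N+]([O-])c1ccccc1CNc1cc(C(F)(F)F)cc2[nH]ncc12` stands second highest of three measured compounds in an assay for inhibition of Indoleamine 2,3-dioxygenase 1 (Homo sapiens), with stated times of 10 min and 60 min, tested at 10 uM (a lower number here means a weaker effect, a higher number a stronger effect of the compound at the concentration tested), where compound 2 gives 35%. Its nearest neighbour is compound 3 `O=[N+]([O-])c1cc(Cl)ccc1CNc1cc(C(F)(F)F)cc2[nH]ncc12`, which in this assay gives 50%; the step of a number 15 percentage points higher from compound 2 to compound 3 (beyond the scatter) arises from chloro in place of hydrogen on an aromatic carbon. The furthest is compound 1 `NCCn1ncc2c(NCc3ccccc3[N+](=O)[O-])cc(C(F)(F)F)cc21`, which in this assay gives 9%; the step of a number 26 percentage points higher from compound 1 to compound 2 (beyond the scatter) arises from hydrogen in place of 2-aminoethyl on an aromatic nitrogen.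

Compound 4 `COC(=O)c1cc(NCc2ccccc2[N+](=O)[O-])c2cn[nH]c2c1` differs from compound 2 at a third place: methoxycarbonyl in place of trifluoromethyl on an aromatic carbon. Within the data shown here, neither measured step touches the trifluoromethyl or the aromatic carbon that carries it, so no measured step bears directly on this change. Both known steps were modest and beyond the scatter, yet they describe other parts of the molecule and give no guidance on exchanging the group on the core of compound 2. Compound 4 is therefore expected to show a step of a number 5 percentage points lower from compound 2 to compound 4 (within the scatter) that does not exceed the scatter. For compound 4 the estimate in this assay is 30%, with a range from 8% to 55%.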

Compound 4, a percentage reported as inhibition, at one concentration (the size of the read-out at that concentration, not a potency): 11%
Estimate against measurement, compound 4: 19 percentage points above, and the stated range covers the measured number.
By their numbers in this assay, from the lowest: compounds 1 and 4 (each within the scatter of the next); then compound 2; then compound 3.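

In this assay, the first step shown at this aromatic carbon of the core is not neutral: methoxycarbonyl in place of trifluoromethyl gives a number 24 percentage points lower from compound 2 to compound 4 (beyond the scatter), so the read-out depends on the group held here as well as on the groups changed in the earlier steps. The exchange keeps the count at 4 heavy atoms and brings in 2 hydrogen-bond acceptors and a double bond outside the aromatic rings, which shows that matching that count does not preserve the read-out, although this single pair cannot say which difference between the two groups matters. Nothing measured here accounts for the size or direction of this step.

The compounds shown leave open how other groups on this carbon, such as a carboxylic acid, a primary amide, a nitrile or a plain methyl, would compare with trifluoromethyl and methoxycarbonyl. They also leave open whether the chloro exchange on the other aromatic ring, seen as a number 15 percentage points higher from compound 2 to compound 3 (beyond the scatter), would carry over to a compound holding methoxycarbonyl at this position.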